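Same atoms, joined differently: from compound 3 to compound 4

The source may report more compounds than this note shows. Statements on the series, on what has been measured and on what is new or still open speak of the compounds shown alone.

Compound 1 `Cc1ccc2[nH]c(C)c(C(=O)NCc3ccc(N4CCC(c5ccc(OC(F)(F)F)cc5)CC4)cc3)c2c1`, compound 2 `Cc1nn2ccc(=O)[nH]c2c1C(=O)NCc1ccc(N2CCC(c3ccc(OC(F)(F)F)cc3)CC2)cc1`, compound 3 `Cc1nc2scc(C)n2c1C(=O)NCc1ccc(N2CCC(c3ccc(OC(F)(F)F)cc3)CC2)cc1` and compound 4 `Cc1nn2c(C)csc2c1C(=O)NCc1ccc(N2CCC(c3ccc(OC(F)(F)F)cc3)CC2)cc1` share most of their structure and differ in the group on a carbonyl carbon. The measurements come from a toxicity assay on Vero cells (Chlorocebus sabaeus) for cytotoxicity, read by CCK-8 assay, with a stated time of 72 h (a lower number here means a stronger inhibitor, a higher number a weaker inhibitor), where a test of this kind shows how strongly a compound harms the cells. In this assay compound 1 is recorded as "not determined" (no result reported). Compound 2 is recorded the same way, as "not determined" (no result reported). Compound 3 gives > 100000 nM, and this is a limit of the assay. The evidence so far therefore amounts to the limit of > 100000 nM in this assay, at which 1 of the 3 values shown sits.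

Compound 4 has the same atoms as compound 3, joined differently. The change sits on a carbonyl carbon whose other neighbour is an amide-type nitrogen: a group of 10 heavy atoms (7 carbon, 2 nitrogen, 1 sulfur; 2 five-membered aromatic rings with 2 hetero atoms each) in place of a group of 10 heavy atoms (7 carbon, 2 nitrogen, 1 sulfur; 2 five-membered aromatic rings with 2 hetero atoms each), on a carbonyl carbon. For the measured compounds named here, no pair of measured compounds shows what a swap of this kind does in this assay, so the expectation rests on compound 3 alone, with its > 100000 nM. No shift in either direction beyond the usual scatter is expected. The estimated step of a number no higher from compound 3 to compound 4 (the limit leaves the size open) is expected to be small, and the assay may well report only a limit again. For compound 4 the estimated value is 100000 nM, with an expected range from 45000 nM to 200000 nM.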

Compound 4, half-maximal inhibitory concentration: > 100000 nM
Compound 4 was reported as a limit; the forecaster's own chance of this, stated with the estimate: 75%; the middle value sits exactly at the limit.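

In this assay, for the compounds shown here, compound 3 and compound 4 are each reported only as a limit of the assay, so no step between them can be read. The compounds shown leave open whether joining the same atoms differently, in the group on the carbonyl carbon, changes how strongly such compounds harm the cells.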